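Swapping the triazolylamino arm for a lactam alkene

This account rests on a few compounds, and the source may have more. Where it says the series, first, only, none or still open, it means among the compounds named here.

Compound 1 `CC(C)C(Nc1nnc[nH]1)c1ccc(-c2ccc3cccc(F)c3c2)[nH]c1=O` carries a (4H-1,2,4-triazol-3-yl)amino group on a saturated chain carbon bound to an aromatic carbon and a saturated chain carbon. In an ADME assay on microsomes from liver (Rattus norvegicus) for metabolic stability (a lower number here means that the compound disappears faster, a higher number that the compound lasts longer), compound 1 gives 1.29 h, the highest of the two plain numbers available. Compound 2 `Cc1nc(C(c2ccc(-c3ccc4cccc(F)c4c3)[nH]c2=O)C(C)C)[nH]c1C`, with 4,5-dimethyl-1H-imidazol-2-yl in that place, gives 0.0733 h in this assay, which is an 18-fold lower number from compound 1 to compound 2 (1.25 log units; beyond the scatter). Compound 3 `CC(C)C(c1noc(=O)[nH]1)c1ccc(-c2ccc3cccc(F)c3c2)[nH]c1=O` gives > 3 h in this assay, and this is only a limit of the measurement (the limit of > 3 h in this assay, at which 1 of the 3 values shown sits). From these, the steps are an at least 2.3-fold higher number from compound 1 to compound 3 (0.36 log units; beyond the scatter) and an at least 40-fold higher number from compound 2 to compound 3 (1.61 log units; beyond the scatter).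

Compound 4 `CC(C)C(/C=C1/CCNC1=O)c1ccc(-c2ccc3cccc(F)c3c2)[nH]c1=O` has not been measured. It differs from compound 1 in one place: a group of 7 heavy atoms (5 carbon, 1 nitrogen, 1 oxygen; one five-membered non-aromatic ring with 1 hetero atom) in place of a group of 6 heavy atoms (2 carbon, 4 nitrogen; one five-membered aromatic ring with 3 hetero atoms), on a saturated chain carbon bound to an aromatic carbon and a saturated chain carbon. The measured step closest to this change is the one toward the ring with 2 hetero atoms in compound 2, which was an 18-fold lower number from compound 1 to compound 2 (1.25 log units; beyond the scatter), while the step toward compound 3 went the other way. A drop beyond the scatter is therefore expected. Compound 4 is expected to give 0.4 h in this assay, between 0.1 h and 1.5 h. That expectation amounts to a 3.2-fold lower number from compound 1 to compound 4 (0.51 log units; beyond the scatter).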

Compound 4, half-life: 0.06 h
Compound 4: the middle estimate sits 6.7-fold (0.82 log units) above what was measured; measured number outside the range, below it.
By their numbers in this assay, from the lowest: compounds 4 and 2 (each within the scatter of the next); then compound 1. At a limit, above all of these: compound 3.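

The new arm, a five-membered non-aromatic ring with 1 hetero atom, gives a 22-fold lower number from compound 1 to compound 4 (1.33 log units; beyond the scatter) in this assay, so a short half-life at this saturated chain carbon is not confined to the 4,5-dimethyl-1H-imidazol-2-yl group. Set against the imidazole, the change is a 1.2-fold lower number from compound 2 to compound 4 (0.09 log units; within the scatter), so these two arms cannot be told apart in this assay, although one ring is aromatic and the other is not. The gap at the top of the series is wide, an at least 50-fold lower number from compound 3 to compound 4 (1.69 log units; beyond the scatter), and the starting value there is a limit rather than a number: the limit of > 3 h in this assay, at which 1 of the 4 values shown sits.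

These arms differ in their ring, their atoms and their hydrogen-bond donors and acceptors all at once, and the compounds shown do not separate those differences. A simple amine or a carboxylic acid on the same carbon, or the same lactam ring joined through a saturated chain, would help to do so.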